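Adding methoxy to compound 3: notes on the series

This account rests on a few compounds, and the source may have more. Where it says the series, first, only, none or still open, it means among the compounds named here.

Measured in a functional assay on U-87MG ATCC cells for antiproliferative activity against U-87 MG (Homo sapiens), read by MTT assay, with a stated time of 48 h; on this read-out higher numbers stand for weaker inhibition and lower numbers for stronger inhibition:
- compound 1 `COc1ccc(-c2nc(C)c(C(=O)CSc3nc(-c4ccc(Cl)cc4)c(C#N)c(=O)[nH]3)s2)cc1`: 45900 nM
- compound 2 `COc1ccc(-c2nc(C)c(C(=O)CSc3nc(-c4ccc(OC)c(OC)c4)c(C#N)c(=O)[nH]3)s2)cc1`: 12500 nM
- compound 3 `Cc1nc(-c2ccccc2)sc1C(=O)CSc1nc(-c2ccc(Cl)c(Cl)c2)c(C#N)c(=O)[nH]1`: 65000 nM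

Compound 3, at 65000 nM, lies within the usual scatter of compound 1, at 45900 nM. Compound 2, at 12500 nM, has a lower number, beyond the scatter of compound 3.

Compound 4 `COc1ccc(-c2nc(C)c(C(=O)CSc3nc(-c4ccc(Cl)c(Cl)c4)c(C#N)c(=O)[nH]3)s2)cc1` differs from compound 3 by methoxy in place of hydrogen on an aromatic carbon, turning phenyl into 4-methoxyphenyl.

Among the compounds with values here, no measured step covers this change. Within the data shown here, the only step available, a 3.7-fold lower number from compound 1 to compound 2 (0.56 log units; beyond the scatter), replaces 4-chlorophenyl with 3,4-dimethoxyphenyl at a different place, so it bears only indirectly. It gives a weak hint towards a lower number, not a size to carry over.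

The expected change is small, a 1.4-fold lower number from compound 3 to compound 4 (0.16 log units; within the scatter), and no step beyond the scatter is expected. For compound 4 the estimated value is 45000 nM, with an expected range of 18000 nM to 110000 nM.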

Compound 4, half-maximal inhibitory concentration: 68500 nM
Beside the measured number, compound 4's estimate is 1.5-fold (0.18 log units) below it; the measured number falls inside the stated range.
By their numbers in this assay, from the lowest: compound 2; then compounds 1, 3 and 4 (each within the scatter of the next).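

In this assay the change from phenyl to 4-methoxyphenyl gives a 1.1-fold higher number from compound 3 to compound 4 (0.02 log units; within the scatter) and so shows no readable change from methoxy at this position when 3,4-dichlorophenyl is held fixed. Chloro in place of hydrogen gives a 1.5-fold higher number from compound 1 to compound 4 (0.17 log units; within the scatter) and is equally unreadable, while 3,4-dichlorophenyl in place of 3,4-dimethoxyphenyl gives a 5.5-fold higher number from compound 2 to compound 4 (0.74 log units; beyond the scatter) and, with 4-methoxyphenyl held fixed, is a step beyond the scatter. The data available offer no explanation for either outcome.

From the compounds shown here alone, it remains open whether phenyl and 4-methoxyphenyl would also read alike with 3,4-dimethoxyphenyl on the other side of the shared core. Also open, going by these compounds, is whether an amine or a carboxylic acid in place of methoxy at this position would move the number beyond the scatter.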